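Bromo in place of methoxy on the aryl ketone

The compounds below may be only part of what the source reports. "The series", "measured", "known", "first", "only" and "open" are said of these compounds alone.

Measured so far in an in vitro assay on Sf9 cells for inhibition of cytochrome P450 2J2 (Homo sapiens); on this read-out higher numbers stand for weaker inhibition and lower numbers for stronger inhibition:
compound 1 `CCc1ccc(C(=O)CCCN2CCC(C(O)(c3ccccc3)c3ccccc3)CC2)cc1` gives 600 nM;
compound 2 `COc1ccc(C(=O)CCCN2CCC(C(O)(c3ccccc3)c3ccccc3)CC2)cc1` gives 7600 nM;
compound 3 `Cc1ccc(C(=O)CCCN2CCC(C(O)(c3ccccc3)c3ccccc3)CC2)cc1` gives 700 nM.

Compound 2 stands at the highest number of the three, so it is the weakest inhibitor measured here. The step from compound 1 to compound 2 reads a 13-fold higher number from compound 1 to compound 2 (1.10 log units; beyond the scatter), and the step from compound 2 to compound 3 reads an 11-fold lower number from compound 2 to compound 3 (1.04 log units; beyond the scatter); both lie well beyond the scatter. The gap between compound 1 and compound 3 is small, a 1.2-fold higher number from compound 1 to compound 3 (0.07 log units; within the scatter).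

Compound 4 `O=C(CCCN1CCC(C(O)(c2ccccc2)c2ccccc2)CC1)c1ccc(Br)cc1` has not been measured. It differs from compound 2 in one place: bromo in place of methoxy on an aromatic carbon. The two large steps above both concern the same methoxy group on the same aromatic carbon, and in each case the compound without the methoxy gives the lower number. Among the compounds with values here, no measured compound carries a bromo group, so the size of the effect of bromo itself is not known from these data. I therefore expect a large step down, a 9.5-fold lower number from compound 2 to compound 4 (0.98 log units; beyond the scatter), and estimate compound 4 at 800 nM, with a range of 250 nM to 3000 nM.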

Compound 4, half-maximal inhibitory concentration: 4200 nM
The estimate for compound 4 lay 5.3-fold (0.72 log units) below the measured number; measured number outside the range, above it.
By their numbers in this assay, from the lowest: compounds 1 and 3 (each within the scatter of the next); then compounds 4 and 2 (each within the scatter of the next).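

In this assay bromo in place of methoxy on this aromatic carbon stays within the scatter (a 1.8-fold lower number from compound 2 to compound 4 (0.26 log units; within the scatter)), so losing the methoxy does not by itself bring the number down to the level of compounds 1 and 3. Bromo in place of the carbon-only groups instead gives modest rises, for methyl (a 6.0-fold higher number from compound 3 to compound 4 (0.78 log units; beyond the scatter)) and for ethyl (a 7.0-fold higher number from compound 1 to compound 4 (0.85 log units; beyond the scatter)), which divides these four compounds into a methyl and ethyl pair with low numbers and a methoxy and bromo pair with high numbers. Nothing available here explains that division.

From the compounds shown here alone, it remains open whether the division holds for other groups on this carbon. Chloro, fluoro, propyl or an amine there, or plain hydrogen, would show which side each falls on.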